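Swapping bromo for trifluoromethyl in a cell tolerance test

This account rests on a few compounds, and the source may have more. Where it says the series, first, only, none or still open, it means among the compounds named here.

compound 1 `Brc1ccc(NCc2cn(-c3ccccc3)nc2-c2ccccc2)cc1` gives 52000 nM
compound 2 `Cc1ccc(NCc2cn(-c3ccccc3)nc2-c2ccc(Cl)cc2)cc1` gives > 100000 nM

Going by the values given here, in an ADME assay on Vero 76 cells (Chlorocebus sabaeus) for cytotoxicity, read by MTT assay, with a stated time of 96 h (a lower number here means that less compound is tolerated, a higher number that more compound is tolerated), compound 1 gives 52000 nM and holds the only true number so far. Compound 2 gives > 100000 nM as a limit of the assay and not a number. Compound 3 `FC(F)(F)c1ccc(NCc2cn(-c3ccccc3)nc2-c2ccccc2)cc1` keeps the core of compound 1 and carries trifluoromethyl in place of bromo on an aromatic carbon, para to a large group (trifluoromethyl in place of bromo on an aromatic carbon). Among the compounds with values here, no measured step shows what this swap does. The expectation therefore starts from compound 1 at 52000 nM and assumes no change beyond the usual scatter in this assay in either direction. The expected step (a 1.1-fold higher number from compound 1 to compound 3 (0.02 log units; within the scatter)) is accordingly small, and a result at the limit of the assay remains possible. Compound 3 is estimated at 55000 nM (expected range 22000 nM to 100000 nM).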

Compound 3, half-maximal cytotoxic concentration: 17000 nM
Estimate against measurement, compound 3: 3.2-fold (0.51 log units) above; measured number outside the range, below it.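

In this assay, putting trifluoromethyl in place of bromo on the aromatic carbon gives a 3.1-fold lower number from compound 1 to compound 3 (0.49 log units; beyond the scatter) and this step lies beyond the usual scatter. The cells therefore tolerate less of compound 3, so the group at this position does matter for tolerance, even though the rest of the molecule stays the same. Going by these compounds alone, this is the first comparison in which only one place changes, but it remains a single pair and sets no trend for other groups.

From the compounds shown here alone, how a nitrile or a carboxylic acid at this position would behave in this assay stays open, as does whether the same swap would have a similar effect on a different core. Nothing shown here explains why trifluoromethyl and bromo differ in this test.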